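The source may report more compounds than this note shows. Statements on the series, on what has been measured and on what is new or still open speak of the compounds shown alone.

Compound 1 `O=S(=O)(Nc1ccc(Oc2ccnc3ccccc23)cc1)c1ccc(C(F)(F)F)cc1Br` was tested in a functional assay on PLC-PRF-5 cells (Homo sapiens) for inhibition; a lower number here means a stronger inhibitor, a higher number a weaker inhibitor. In this assay compound 1 gives > 40000 nM, which is a limit of the assay and not a number. Compound 2 `O=[N+]([O-])c1cccc2c(Oc3ccc(NS(=O)(=O)c4ccc(C(F)(F)F)cc4Br)cc3)ccnc12` carries nitro in place of hydrogen on an aromatic carbon. In this assay compound 2 gives > 40000 nM, again a limit rather than a number. The step that the two limits leave unreadable from compound 1 to compound 2 therefore cannot be read, because of the limit of > 40000 nM in this assay, at which 2 of the 3 values shown sit. Compound 3 `O=C(Nc1ccc(Oc2ccnc3ccccc23)cc1)c1cc(C(F)(F)F)cc(C(F)(F)F)c1` rests on another core; the difference between the two cores is not broken down here. In this assay, among the measured compounds shown here, compound 3 gives 16000 nM, the only number among the three measured compounds. Compound 4 `O=C(Nc1ccc(Oc2ccnc3c([N+](=O)[O-])cccc23)cc1)c1cc(C(F)(F)F)cc(C(F)(F)F)c1` carries the same change, (nitro in place of hydrogen on an aromatic carbon), made on compound 3, so this change appears twice among the compounds shown. In this assay the expected step is no change at the digits printed from compound 3 to compound 4 (within the scatter). This expectation rests on compound 3 giving 16000 nM. The step that the two limits leave unreadable from compound 1 to compound 2 cannot be read, so the change itself brings no readable size with it. For compound 4 the estimate in this assay is 16000 nM, expected to fall between 5000 nM and 40000 nM.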

Compound 4, half-maximal inhibitory concentration: > 40000 nM
Compound 4 gave a limit, no number; the forecaster's own chance of this, stated with the estimate: 30%; at least 2.5-fold (0.39 log units) between middle value and limit.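

On the core of compound 3, nitro in place of hydrogen on an aromatic carbon gives in this assay an at least 2.5-fold higher number from compound 3 to compound 4 (0.39 log units; beyond the scatter), so on this core the change goes with weaker inhibition. From the compounds shown here alone, compound 4 gives > 40000 nM, which is a limit of the assay and not a number, so the full size of this step stays unknown. The same change on the core of compound 1 cannot be read, and the two steps cannot be set side by side to say whether the change carries from one core to the other, because of where the values sit: the limit of > 40000 nM in this assay, at which 3 of the 4 values shown sit.

The compounds shown leave open whether an amine or a carboxylic acid on that same aromatic carbon would move the value as nitro does. They also leave open whether any replacement on the core of compound 1 would bring it to a readable number in this assay.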